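The compounds below may be only part of what the source reports. "The series", "measured", "known", "first", "only" and "open" are said of these compounds alone.

Compound 1 `Cc1ccc(N2CCN(CCCCOc3ccc4c(=O)cc(-c5ccccc5)oc4c3)CC2)cc1` and compound 2 `Cc1ccccc1N1CCN(CCCCOc2ccc3c(=O)cc(-c4ccccc4)oc3c2)CC1` share one core and differ only in the group attached to an amine nitrogen in a ring. In a functional assay for antagonist activity at Adrenergic receptor alpha-1 (Rattus norvegicus) (a higher number here means weaker binding, a lower number tighter binding), compound 1 gives 195 nM, while compound 2 gives 19.5 nM. The change between them is 2-methylphenyl in place of 4-methylphenyl on an amine nitrogen in a ring and it made a 10-fold lower number from compound 1 to compound 2 (1.00 log units; beyond the scatter). Compound 3 `Cc1ccc(N2CCN(CCCOc3ccc4c(=O)cc(-c5ccc(Cl)cc5)oc4c3)CC2)cc1` carries the 4-methylphenyl group on a second core, and the difference between the two cores is not broken down here. In this assay compound 3 gives 8.17 nM, the lowest number among the three measured compounds, with compound 2 nearest and compound 1 furthest. Compound 4 `Cc1ccccc1N1CCN(CCCOc2ccc3c(=O)cc(-c4ccc(Cl)cc4)oc3c2)CC1` has not yet been measured. It differs from compound 3 by 2-methylphenyl in place of 4-methylphenyl on an amine nitrogen in a ring, the same change as from compound 1 to compound 2, at a place described in the same words. A step of similar direction is expected here because the earlier pair made a 10-fold lower number from compound 1 to compound 2 (1.00 log units; beyond the scatter), and the expected change from compound 3 to compound 4 is a 6.8-fold lower number from compound 3 to compound 4 (0.83 log units; beyond the scatter). This rests on a single measured pair, so some caution is warranted. Compound 4 is therefore estimated to give about 1.2 nM in this assay, most likely between 0.4 nM and 4 nM.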

Compound 4, dissociation constant: 16.9 nM
Beside the measured number, compound 4's estimate is 14-fold (1.15 log units) below it; measured number outside the range, above it.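

In this assay, placing 2-methylphenyl where 4-methylphenyl stood on the core of compound 3 gave a 2.1-fold higher number from compound 3 to compound 4 (0.32 log units; beyond the scatter), so the number rose on this core instead of falling. Set side by side, the two results show that this change does not carry a fixed effect from one core to the other in this series, and a step measured on one core is a poor guide to the same step on the other: the same change on two cores in this assay, a 10-fold lower number (1.00 log units; beyond the scatter) from compound 1 to compound 2 and a 2.1-fold higher number (0.32 log units; beyond the scatter) from compound 3 to compound 4, 21-fold (1.32 log units) apart, beyond the scatter of two such steps

For the compounds shown here, what this does not show is which part of the cores is responsible, as they differ in more than one place and no pair here separates those differences.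

On these data alone, it remains open how other groups on the same amine nitrogen in a ring, such as 2-methoxyphenyl or 2-chlorophenyl, would behave on each core. Also open, as far as these compounds go, is which of the two results a third core, for instance one with a longer chain, would resemble.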